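This account rests on a few compounds, and the source may have more. Where it says the series, first, only, none or still open, it means among the compounds named here.

Measured so far in a functional assay on HepG2 cells (Homo sapiens) for cytotoxicity, read by MTT assay, with a stated time of 72 h; on this read-out lower numbers stand for stronger inhibition and higher numbers for weaker inhibition:
- Compound 1 `CNC(=O)c1cc(Oc2ccc(C(=O)/C=C/c3cccc(Br)c3)cc2)ccn1`: 2870 nM
- Compound 2 `CNC(=O)c1cc(Oc2ccc(C(=O)/C=C/c3ccc(Cl)c(Cl)c3)cc2)ccn1`: 11400 nM
- Compound 3 `CNC(=O)c1cc(Oc2ccc(C(=O)/C=C/c3ccc(OC)c(OC)c3OC)cc2)ccn1`: 9810 nM

Compound 2, together with compound 3, stands at the upper end of these numbers, and the two values lie within the scatter of each other. Compound 4 `CNC(=O)c1cc(Oc2ccc(C(=O)/C=C/c3ccc(F)cc3Cl)cc2)ccn1` alters one group of compound 2: 2-chloro-4-fluorophenyl in place of 3,4-dichlorophenyl on a double-bonded chain carbon bound to a double-bonded chain carbon. Within the data shown here, the only measured step at this place is a 4.0-fold higher number from compound 1 to compound 2 (0.60 log units; beyond the scatter), a modest one, so a swap of this phenyl group can move the number in this assay. That single step does not settle the direction for the new group, though compound 1 at 2870 nM shows that lower numbers occur here. The expected change is therefore small, a 1.8-fold lower number from compound 2 to compound 4 (0.24 log units; within the scatter). For compound 4 the estimated value is 6500 nM, with an expected range from 2200 nM to 16000 nM.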

Compound 4, half-maximal inhibitory concentration: 7320 nM
For compound 4 the middle estimate is 1.1-fold (0.05 log units) below the measured one; low and high end bracket the measured number.
By their numbers in this assay, from the lowest: compound 1; then compounds 4, 3 and 2 (each within the scatter of the next).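

In this assay, 2-chloro-4-fluorophenyl in place of 3,4-dichlorophenyl gives a 1.6-fold lower number from compound 2 to compound 4 (0.19 log units; within the scatter), so this swap of chlorine and fluorine atoms on the phenyl group shows no clear effect. The change from 3-bromophenyl gives a 2.6-fold higher number from compound 1 to compound 4 (0.41 log units; beyond the scatter), so compound 4, like compound 2, stands apart from compound 1. Nothing measured here explains these differences.

The compounds shown leave open whether the lower number of compound 1 comes from the bromine atom itself or from where it sits. They also leave open how a phenyl group carrying an amine or a carboxylic acid would behave.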